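From methyl to propyl: a step not yet measured

The source may hold more compounds than are shown below. What is called first, only, known or untested is meant among the compounds shown, and "the series" means these compounds.

Measured in a functional assay on cells (Homo sapiens) for inhibition, read by MTT assay, with a stated time of 48 h; a lower number here means a stronger inhibitor, a higher number a weaker inhibitor:
- compound 1 `O=C(COCCOc1no[n+]([O-])c1S(=O)(=O)c1ccccc1)NO` gives 19800 nM
- compound 2 `CC(C)(COc1no[n+]([O-])c1S(=O)(=O)c1ccccc1)C(=O)NO` gives 18300 nM

Within the data shown here, compound 2 stands within the scatter of compound 1, the only other measured compound, so the two cannot be ranked. Compound 3 `CCCC(C)(COc1no[n+]([O-])c1S(=O)(=O)c1ccccc1)C(=O)NO` differs from compound 2 in one place: ethyl in place of hydrogen on a saturated chain carbon, two bonds along the chain from a carbonyl carbon. This is ethyl in place of hydrogen on a saturated chain carbon, two bonds along the chain from a carbonyl carbon, and it can also be read as methyl to propyl. Among the measured compounds shown here, the only measured step is a 1.1-fold lower number from compound 1 to compound 2 (0.03 log units; within the scatter). It is a different change and offers limited guidance, but it gives no sign of a large shift in this assay. The estimated step is a 1.1-fold lower number from compound 2 to compound 3 (0.06 log units; within the scatter), which means none is expected beyond the scatter. For compound 3 the expected value is 16000 nM, with an estimated range of 8000 nM to 32000 nM.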

Compound 3, half-maximal inhibitory concentration: 88700 nM
Compound 3: middle estimate off by 5.5-fold (0.74 log units), on the low side; the measured number lies above the stated range.
By their numbers in this assay, from the lowest: compounds 2 and 1 (each within the scatter of the next); then compound 3.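

In this assay this saturated chain carbon, two bonds along the chain from a carbonyl carbon, proved sensitive to substitution: ethyl in place of hydrogen gave a 4.8-fold higher number from compound 2 to compound 3 (0.69 log units; beyond the scatter), a weaker inhibitor by a step beyond the scatter. The earlier compounds shown here could not show this, since compound 1 and compound 2 differ by another change and stand within the scatter of each other. Nothing available here explains the rise.

The compounds shown leave open how the number responds to other groups on this carbon, such as a single methyl, a longer chain like butyl, or a chain ending in an amine or a carboxylic acid. They also leave open whether phenyl there would give a number nearer that of compound 2 or compound 3.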